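Swapping the chlorobenzyl amine for an ethylpiperazine

This account rests on a few compounds, and the source may have more. Where it says the series, first, only, none or still open, it means among the compounds named here.

Three analogues sharing one core have been tested in a functional assay on HCT-116 cells (Homo sapiens) for inhibition, read by MTT assay, with a stated time of 72 h; a lower number here means a stronger inhibitor, a higher number a weaker inhibitor. Compound 1 `CNCc1c(OC)cc(Oc2cccc(Nc3ccccc3)c2)cc1OC` gives only the limit > 20000 nM, not a number. Compound 2 `COc1cc(Oc2cccc(Nc3ccccc3)c2)cc(OC)c1CN[C@H](C)c1ccccc1` likewise reaches only the limit > 20000 nM. Among the compounds with values here, compound 3 `COc1cc(Oc2cccc(Nc3ccccc3)c2)cc(OC)c1CNCc1ccc(Cl)cc1` is the one member with a measured value, 3310 nM in this assay, so it stands as the only quantified point of the set; the other two sit at the limit of > 20000 nM in this assay, at which 2 of the 3 values shown sit. The steps toward it are an at least 6.0-fold lower number from compound 1 to compound 3 (0.78 log units; beyond the scatter) and an at least 6.0-fold lower number from compound 2 to compound 3 (0.78 log units; beyond the scatter), each readable only as a bound because the starting points are limits.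

Compound 4 `CCN1CCN(Cc2c(OC)cc(Oc3cccc(Nc4ccccc4)c3)cc2OC)CC1` differs from compound 3 by 4-ethylpiperazin-1-yl in place of (4-chlorobenzyl)amino on a saturated chain carbon bound to an aromatic carbon. The gain seen on going from compound 1 to compound 3 came with the 4-chlorophenyl group, and that group now leaves, while the group that enters resembles neither of the measured amine substituents. The expected step is therefore a 4.5-fold higher number from compound 3 to compound 4 (0.66 log units; beyond the scatter), a higher number, probably beyond the scatter. Compound 4 is estimated at 15000 nM in this assay, within 4000 nM to 50000 nM, with a fair chance that only a limit is reported.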

Compound 4, half-maximal inhibitory concentration: > 20000 nM
Compound 4 gave a limit, no number; the forecaster's own chance of this, stated with the estimate: 50%; middle value at least 1.3-fold (0.12 log units) from the limit.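

At the saturated chain carbon bound to an aromatic carbon, 4-ethylpiperazin-1-yl in place of (4-chlorobenzyl)amino gives, in this assay, an at least 6.0-fold higher number from compound 3 to compound 4 (0.78 log units; beyond the scatter). Compound 4 reaches only a limit, not a number, and so joins the other unquantified compounds: the limit of > 20000 nM in this assay, at which 3 of the 4 values shown sit. Within the data shown here, a measured value in this set therefore remains confined to compound 3, the only one carrying the 4-chlorophenyl group, while the steps from compound 1 and compound 2 to compound 4 join two limits and cannot be read.

The compounds shown do not separate the loss of the 4-chlorophenyl group from the arrival of the piperazine ring. From the compounds shown here alone, whether a 4-(4-chlorobenzyl)piperazin-1-yl group, or an unsubstituted benzylamine, would give a measured value in this place remains open.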